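A few compounds are considered here, and "the series" means these few. Any claim that something is new, unique, unknown or untested is made for them only; others in the source may bear on it.

Compound 1 `Cc1cc(-c2c(F)cc3c(=O)ccn(C4CC4)c3c2F)cc(C)n1` is the unsubstituted member of the set. In a functional assay on P388 cells (Mus musculus) for cytotoxicity (on this read-out higher numbers stand for weaker inhibition and lower numbers for stronger inhibition), compound 1 gives 15000 nM, the highest of the three numbers on hand and therefore the weakest inhibition measured so far. Compound 2 `Cc1cc(-c2c(F)cc3c(=O)c(Cc4ccccc4O)cn(C4CC4)c3c2F)cc(C)n1` carries a 2-hydroxybenzyl group on the same aromatic carbon; in this assay compound 2 gives 670 nM. Compound 3 `Cc1cc(-c2c(F)cc3c(=O)c(Cc4ccccc4N)cn(C4CC4)c3c2F)cc(C)n1` carries a 2-aminobenzyl group at that carbon, and in this assay compound 3 gives 2100 nM. The two steps from the parent are a 22-fold lower number from compound 1 to compound 2 (1.35 log units; beyond the scatter) and a 7.1-fold lower number from compound 1 to compound 3 (0.85 log units; beyond the scatter); between the two substituted compounds the step is a 3.1-fold higher number from compound 2 to compound 3 (0.50 log units; beyond the scatter).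

Compound 4 `Cc1cc(-c2c(F)cc3c(=O)c(Cc4ccc(O)cc4)cn(C4CC4)c3c2F)cc(C)n1` is the next entry. Relative to compound 1 the change is 4-hydroxybenzyl in place of hydrogen on an aromatic carbon. Both measured steps from compound 1 bear on this change, since each also places a substituted benzyl group on the same carbon: the hydroxy case, a 22-fold lower number from compound 1 to compound 2 (1.35 log units; beyond the scatter), was large, and the amino case, a 7.1-fold lower number from compound 1 to compound 3 (0.85 log units; beyond the scatter), modest. The 4-hydroxybenzyl group keeps the hydroxy of compound 2, so a drop of comparable size is expected, though whether moving the hydroxy within the benzyl group changes anything is not told by this set. The expected step is a 15-fold lower number from compound 1 to compound 4 (1.18 log units; beyond the scatter), toward stronger inhibition. Compound 4 is estimated at 1000 nM in this assay, with a range of 300 nM to 3500 nM.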

Compound 4, half-maximal inhibitory concentration: 1500 nM
Estimate against measurement, compound 4: 1.5-fold (0.18 log units) below, within the range that was stated.
By their numbers in this assay, from the lowest: compound 2; then compounds 4 and 3 (each within the scatter of the next); then compound 1.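

In this assay, the hydroxy group can now be compared at two places on the benzyl group, and its place matters beyond the scatter (a 2.2-fold higher number from compound 2 to compound 4 (0.35 log units; beyond the scatter)), with the 2-hydroxybenzyl group of compound 2 giving the lower number of the pair. The 4-hydroxybenzyl group still gives a clear drop from the parent (a 10-fold lower number from compound 1 to compound 4 (1.00 log units; beyond the scatter)), so all three substituted benzyl groups on this aromatic carbon give lower numbers than compound 1. The 2-aminobenzyl and 4-hydroxybenzyl groups cannot be told apart (a 1.4-fold lower number from compound 3 to compound 4 (0.15 log units; within the scatter)), even though they differ in both the substituent and its place on the benzyl group, and no measurement on hand gives a reason for any of these differences.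

Still open, going by these compounds, is how a 3-hydroxybenzyl or a 4-aminobenzyl group would read at this carbon, and whether a plain benzyl or a 2-methoxybenzyl group would keep the drop seen with the hydroxy compounds. Also open, on these data alone, is whether the benzyl ring is needed at all, a question that a hydroxymethyl group or a carboxylic acid on the same carbon would address.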